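Adding a methoxy group to compound 2

The compounds below may be only part of what the source reports. "The series", "measured", "known", "first", "only" and "open" are said of these compounds alone.

In a functional assay on RPMI-8226 cells (Homo sapiens) for cytotoxicity, with a stated time of 72 h (on this read-out lower numbers stand for an effect already at smaller amounts and higher numbers for an effect only at larger amounts of compound), compound 1 `CC(C)=CCC/C(C)=C/Cc1c(O)cc2c(c1O)C(=O)C[C@@H](c1cc(O)cc(O)c1)O2` gives 7100 nM. Compound 2 `CC(C)=CCC/C(C)=C/Cc1c(O)cc2c(c1O)C(=O)C[C@@H](c1ccc(O)c(O)c1)O2` is reported only as a limit, < 10000 nM. Among the compounds with values here, the one measured step is a step that the limit leaves unreadable from compound 1 to compound 2, which has no readable size because of the limit of < 10000 nM in this assay, at which 1 of the 2 values shown sits. Compound 3 `COc1cc([C@@H]2CC(=O)c3c(cc(O)c(C/C=C(\C)CCC=C(C)C)c3O)O2)cc(O)c1O` differs from compound 2 by methoxy in place of hydrogen on an aromatic carbon. Within the data shown here, no measured step covers this change, so no shift beyond the usual scatter is expected. The expected step is a step that the limit leaves unreadable from compound 2 to compound 3. For compound 3 the estimated value is 7000 nM, with an expected range of 3000 nM to 15000 nM.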

Compound 3, half-maximal effective concentration: 7300 nM
The estimate for compound 3 lay 1.0-fold (0.02 log units) below the measured number, and the stated range covers the measured number.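

Within the data shown here, the one step that can be read is a 1.0-fold higher number from compound 1 to compound 3 (0.01 log units; within the scatter) in this assay, so a 3,4-dihydroxy-5-methoxyphenyl group in place of 3,5-dihydroxyphenyl brings no shift beyond the scatter. The step from compound 2 to compound 3 cannot be read, so what the methoxy group alone contributes stays unknown, because compound 2 carries only a limit: the limit of < 10000 nM in this assay, at which 1 of the 3 values shown sits.

On these data alone, what an amine, a carboxylic acid or a longer ether chain in place of the methoxy group would do on this aromatic carbon remains open.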